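Methoxy in place of methyl on the aryl of compound 2

A few compounds are considered here, and "the series" means these few. Any claim that something is new, unique, unknown or untested is made for them only; others in the source may bear on it.

compound 1, `Cc1ccc(-c2nn(-c3ccccc3)cc2C(=O)NOCc2ccccc2F)cc1`: 260 nM
compound 2, `Cc1ccc(-c2nn(-c3ccccc3)cc2C(=O)NOCc2ccccc2Cl)cc1`: 380 nM
compound 3, `Cc1ccc(-c2nn(-c3ccccc3)cc2C(=O)NOCc2ccc(Cl)cc2Cl)cc1`: 1080 nM

In a functional assay on A549 cells (Homo sapiens) for antiproliferative activity, read by MTT assay, with a stated time of 48 h, in the presence of a further agent that is not named here (a lower number here means a stronger inhibitor of growth, a higher number a weaker inhibitor of growth), compound 2 gives 380 nM, the second highest of the three numbers. Its nearest neighbour is compound 1, and that step, a 1.5-fold higher number from compound 1 to compound 2 (0.16 log units; within the scatter), lies within the scatter. Compound 3 is further off: a 2.8-fold higher number from compound 2 to compound 3 (0.45 log units; beyond the scatter), and the related step of a 4.2-fold higher number from compound 1 to compound 3 (0.62 log units; beyond the scatter) points the same way.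

Compound 4, `COc1ccc(-c2nn(-c3ccccc3)cc2C(=O)NOCc2ccccc2Cl)cc1`, differs from compound 2 in one place: methoxy in place of methyl on an aromatic carbon. Within the data shown here, none of the measured steps bears directly on this position; all three of them alter the group on the saturated chain carbon bound to an oxygen at the other end of the shared core, and the aryl carrying the methyl is unchanged throughout. Among the measured compounds shown here, there is therefore no measured step from which a shift in this assay can be read, and the expectation is a step no larger than the scatter: a 1.1-fold higher number from compound 2 to compound 4 (0.02 log units; within the scatter). Compound 4 is accordingly expected to give about 400 nM, with a likely range from 150 nM to 1100 nM.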

Compound 4, concentration for 50% growth inhibition: 2450 nM
Estimate against measurement, compound 4: 6.1-fold (0.79 log units) below; measured number above the stated range.
By their numbers in this assay, from the lowest: compounds 1 and 2 (each within the scatter of the next); then compound 3; then compound 4.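

The first change shown on this aryl, methoxy in place of methyl on an aromatic carbon, gives in this assay a 6.4-fold higher number from compound 2 to compound 4 (0.81 log units; beyond the scatter), so this position, unchanged across compounds 1, 2 and 3, is not indifferent to substitution. The change adds one heavy atom and one hydrogen-bond acceptor and goes with weaker inhibition of growth, but this single pair cannot show which of these differences matters. Nothing available here explains the shift.

The compounds shown carry only methyl and methoxy at this position, so it remains open whether an ethyl, a hydroxyl or a fluoro there would stay close to compound 2 or fall nearer compound 4. They also leave open whether the same change would give a similar step on compound 1, which carries 2-fluorophenyl at the other end.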